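The compounds below may be only part of what the source reports. "The series", "measured", "known", "first", "only" and "open" are said of these compounds alone.

Measured in an assay on membranes from Cortex for displacement of a labelled ligand from Sigma non-opioid intracellular receptor 1 (Cavia porcellus), read by scintillation counting, with a stated time of 120 min; a lower number here means a stronger inhibitor, a higher number a weaker inhibitor:
compound 1, `Fc1ccc(CN2CCC(NCCSC(c3ccc(F)cc3)c3ccc(F)cc3)CC2)cc1`, 13.3 nM
compound 2, `O=C(c1ccc(F)cc1)N1CCC(NCCSC(c2ccc(F)cc2)c2ccc(F)cc2)CC1`, 32.1 nM
compound 3, `O=C(c1cc2ccccc2o1)N1CCC(NCCSC(c2ccc(F)cc2)c2ccc(F)cc2)CC1`, 304 nM

Compound 3 gives the highest number of the three. The step of a 9.5-fold higher number from compound 2 to compound 3 (0.98 log units; beyond the scatter) and the step of a 23-fold higher number from compound 1 to compound 3 (1.36 log units; beyond the scatter) both lie beyond the scatter, so compound 3 is the weakest inhibitor in this set; the step of a 2.4-fold higher number from compound 1 to compound 2 (0.38 log units; beyond the scatter) is smaller but also beyond the scatter.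

Compound 4, `O=C(c1cc2ccccc2[nH]1)N1CCC(NCCSC(c2ccc(F)cc2)c2ccc(F)cc2)CC1`, keeps the core of compound 3 and differs in one place: 1H-indol-2-yl in place of 1-benzofuran-2-yl on a carbonyl carbon. Among the compounds with values here, no measured pair covers an exchange of this kind. The nearest comparison is a 9.5-fold higher number from compound 2 to compound 3 (0.98 log units; beyond the scatter), where the group on the carbonyl carbon was exchanged for one with a different ring count and a different heavy-atom count, and the number rose. The exchange in compound 4 keeps the same ring pattern and the same heavy-atom count, so a step smaller than a 9.5-fold higher number from compound 2 to compound 3 (0.98 log units; beyond the scatter) is expected, in either direction, with no confident call on the sign. The step is expected to be a 1.5-fold lower number from compound 3 to compound 4 (0.18 log units; within the scatter). For compound 4 in this assay the estimate is 200 nM, with a range from 60 nM to 700 nM.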

Compound 4, inhibition constant: 1130 nM
Estimate against measurement, compound 4: 5.7-fold (0.75 log units) below; measured number above the stated range.
By their numbers in this assay, from the lowest: compound 1; then compound 2; then compound 3; then compound 4.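

In this assay, the group on the carbonyl carbon proves sensitive even to an exchange that keeps the ring pattern and the heavy-atom count: 1H-indol-2-yl in place of 1-benzofuran-2-yl gives a 3.7-fold higher number from compound 3 to compound 4 (0.57 log units; beyond the scatter) and differs only in nitrogen for oxygen and in the hydrogen-bond donor and acceptor counts. The same group also widens the gaps to the other two compounds, with a 35-fold higher number from compound 2 to compound 4 (1.55 log units; beyond the scatter) on exchanging 4-fluorophenyl on a carbonyl carbon and an 85-fold higher number from compound 1 to compound 4 (1.93 log units; beyond the scatter) on exchanging 4-fluorobenzyl for (1H-indol-2-yl)carbonyl on an amine nitrogen in a ring, which makes compound 4 the weakest inhibitor of the four. Nothing at hand explains the rise in the number on going to the 1H-indol-2-yl group.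

Open, as far as these compounds go, is whether the hydrogen on the indole nitrogen goes with this rise, a question that 1-methyl-1H-indol-2-yl or 1-benzothiophen-2-yl on the same carbonyl carbon would address. Also open is whether the order among these groups holds without the carbonyl, as with 1-benzofuran-2-ylmethyl or 1H-indol-2-ylmethyl on the amine nitrogen in a ring.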